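Aryl swap at the ring nitrogen of compound 1

This account rests on a few compounds, and the source may have more. Where it says the series, first, only, none or still open, it means among the compounds named here.

Measured so far:
compound 1 `C[C@H](Nc1ncnc2[nH]cnc12)c1nn(-c2cccnc2)c2cc(F)ccc12` — 23%
compound 2 `CC[C@H](Nc1ncnc2[nH]cnc12)c1nn(-c2cccnc2)c2cc(F)ccc12` — 26%
compound 3 `C[C@H](Nc1nc(N)nc2[nH]cnc12)c1nn(-c2cccnc2)c2cc(F)ccc12` — 11%

In a functional assay on HepG2 cells (Homo sapiens) for inhibition, read by sulforhodamine B assay, with a stated time of 72 h, tested at 10 uM (a lower number here means less inhibition, a higher number more inhibition at the concentration tested (going by the name of the read-out)), compound 1 stands second highest of the three numbers; nearest is compound 2 with a number 3 percentage points higher from compound 1 to compound 2 (within the scatter), furthest is compound 3 with a number 12 percentage points lower from compound 1 to compound 3 (beyond the scatter). Compound 4 `C[C@H](Nc1ncnc2[nH]cnc12)c1nn(-c2cccc(F)c2)c2cc(F)ccc12` differs from compound 1 by 3-fluorophenyl in place of pyridin-3-yl on an aromatic nitrogen. Neither measured step touches this position: one alters a saturated chain carbon, the other an aromatic carbon of the shared core, so neither bears directly on the change, and both steps were small. Among the compounds with values here, no measured pair gives a direct precedent for the aryl exchange. Compound 4 is expected to give no change at the digits printed from compound 1 to compound 4 (within the scatter), within the scatter. Compound 4 is estimated at 23%, with a range from 8% to 40%.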

Compound 4, a percentage reported as inhibition, at one concentration (the size of the read-out at that concentration, not a potency): 33%
Beside the measured number, compound 4's estimate is 10 percentage points below it; measured number inside the range.
By their numbers in this assay, from the lowest: compound 3; then compounds 1, 2 and 4 (each within the scatter of the next).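

In this assay, within the data shown here, 3-fluorophenyl in place of pyridin-3-yl on the aromatic nitrogen gives a number 10 percentage points higher from compound 1 to compound 4 (within the scatter) and is the first measured step at this position. The position therefore accepts an aryl ring of carbon only, with no hydrogen-bond acceptor, and the step stays within the scatter. Nothing available accounts for the step or assigns it to the fluorine or to the ring nitrogen.

Which part of the exchange matters remains open, the fluorine or the ring nitrogen. Also open, as far as these compounds go, is how a plain phenyl, or an aryl ring carrying an amine or a carboxylic acid, would read at this place.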